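Ethoxy to propoxy: the step to compound 3

This account rests on a few compounds, and the source may have more. Where it says the series, first, only, none or still open, it means among the compounds named here.

Measured in a functional assay on SK-BR-3 cells (Homo sapiens) for antiproliferative activity, read by MTT assay, with a stated time of 72 h; a higher number here means a weaker inhibitor, a lower number a stronger inhibitor:
- compound 1 `C/C=C1/[C@H](O[C@@H]2O[C@H](COC(C)=O)[C@@H](OC(C)=O)[C@H](OC(C)=O)[C@H]2OC(C)=O)OC=C(C(=O)OC)[C@H]1CC(=O)SCCC`: > 15000 nM, a limit
- compound 2 `C/C=C1/[C@H](O[C@@H]2O[C@H](COC(C)=O)[C@@H](OC(C)=O)[C@H](OC(C)=O)[C@H]2OC(C)=O)OC=C(C(=O)OC)[C@H]1CC(=O)OCC`: > 15000 nM, a limit

Compound 2 stands at > 15000 nM, which is a limit of the assay and not a number. The two compounds together rest on (the limit of > 15000 nM in this assay, at which 2 of the 2 values shown sit), so no measured number exists yet in this series.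

Compound 3 `C/C=C1/[C@H](O[C@@H]2O[C@H](COC(C)=O)[C@@H](OC(C)=O)[C@H](OC(C)=O)[C@H]2OC(C)=O)OC=C(C(=O)OC)[C@H]1CC(=O)OCCC` differs from compound 2 by methyl in place of hydrogen on a saturated chain carbon, two bonds along the chain from an oxygen next to a carbonyl group. Put in other words, this is ethoxy to propoxy.

Among the measured compounds shown here, one measured step bears on this change, and only loosely: a step that the two limits leave unreadable from compound 1 to compound 2. It has no readable size, so it offers no magnitude to carry over, and it concerns a different exchange on the same carbonyl carbon. The expectation therefore rests on compound 2 at > 15000 nM, and no gain in this assay beyond the scatter is expected, with a further report as a limit the likeliest outcome.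

The expected step is a step that the limit leaves unreadable from compound 2 to compound 3. The estimate for compound 3 is 20000 nM, with an expected range from 10000 nM to 40000 nM.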

Compound 3, half-maximal inhibitory concentration: 6600 nM
Beside the measured number, compound 3's estimate is 3.0-fold (0.48 log units) above it; the whole stated range lies above it.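

In this assay, among the compounds shown here, compound 3 is the first compound to give a measured number, and the change from ethoxy to propoxy brings an at least 2.2-fold lower number from compound 2 to compound 3 (0.35 log units; beyond the scatter). With propyl kept on the same carbonyl carbon, the exchange of propylsulfanyl for propoxy brings an at least 2.2-fold lower number from compound 1 to compound 3 (0.35 log units; beyond the scatter), so the atom joining the chain to the carbonyl carbon and the chain itself can each separate a measurable compound from one at the limit. Both steps are minimum sizes, the step between compound 1 and compound 2 cannot be read, and the two starting compounds give no number: the limit of > 15000 nM in this assay, at which 2 of the 3 values shown sit.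

With propoxy as the only chain here that carries a measured number, the trend with chain length remains undefined, and a butoxy or longer alkoxy chain on the same carbonyl carbon would show whether the number keeps falling or turns back. Also open, as far as these compounds go, is how a propylamino group or a free carboxylic acid at that carbonyl carbon would read in this assay.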